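Cyclopropylmethyl for Propyl on the Amine of Compound 2

The compounds below may be only part of what the source reports. "The series", "measured", "known", "first", "only" and "open" are said of these compounds alone.

Three compounds share one core and were compared in an assay on cell membranes for displacement of a labelled ligand from corticotropin-releasing factor receptor 1 (Rattus norvegicus); on this read-out higher numbers stand for weaker inhibition and lower numbers for stronger inhibition. Compound 1 `CCN(CC)c1nc(C)nc2c(-c3cnc(OC)cc3C)c(C)nn12` gives 14.5 nM in this assay. Compound 2 `CCCN(CCC)c1nc(C)nc2c(-c3ccc(OC)nc3C)c(C)nn12` gives 5.7 nM in this assay. Compound 3 `CCCCN(CCC)c1nc(C)nc2c(-c3c(C)cc(N(C)C)nc3C)c(C)nn12` gives 12.8 nM in this assay. On these numbers compound 2 stands lowest, with compound 3 nearest to it and compound 1 furthest, and both of those gaps lie beyond the usual scatter, so compound 2 is the strongest inhibitor of the three.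

Compound 4 `CCCN(CC1CC1)c1nc(C)nc2c(-c3ccc(OC)nc3C)c(C)nn12` has not yet been measured in this assay. It differs from compound 2 in one place: cyclopropyl in place of ethyl on a saturated chain carbon bound to a nitrogen on an aromatic ring. The dipropylamino becomes (cyclopropylmethyl)(propyl)amino; nothing else moves.

Within the data shown here, no pair of measured compounds shows this change, so its effect is open. Since the change is small and keeps the chain on the nitrogen, the step from compound 2 to compound 4 is expected to be modest and within the scatter, as a 1.1-fold lower number from compound 2 to compound 4 (0.06 log units; within the scatter) expresses. Compound 4 is therefore estimated to give 5 nM in this assay, within a range from 2 nM to 15 nM.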

Compound 4, half-maximal inhibitory concentration: 1.6 nM
For compound 4 the middle estimate is 3.1-fold (0.49 log units) above the measured one, outside the stated range (below it).
By their numbers in this assay, from the lowest: compound 4; then compound 2; then compounds 3 and 1 (each within the scatter of the next).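

In this assay, exchanging one propyl for cyclopropylmethyl on the amine, with the rest of the molecule unchanged, gives a 3.6-fold lower number from compound 2 to compound 4 (0.55 log units; beyond the scatter). This shows that a change of a single carbon and one three-membered ring at this place can move the number beyond the scatter, something compounds 1, 2 and 3 could not show, as they differ from one another in more than one place. Nothing given here accounts for the size of this step.

The compounds shown leave open whether a second cyclopropylmethyl in place of the remaining propyl, a cyclobutylmethyl or a methoxyethyl chain would behave in the same way. They also leave open whether the same exchange would give a similar step on the aromatic groups carried by compound 1 and compound 3.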